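The source may hold more compounds than are shown below. What is called first, only, known or untested is meant among the compounds shown, and "the series" means these compounds.

Measured in an ADME assay on A549 cells (Homo sapiens) for cytotoxicity, read by resazurin assay, with a stated time of 48 h; on this read-out lower numbers stand for higher toxicity in this test and higher numbers for lower toxicity in this test:
compound 1 `CCNc1ccc(NC(=O)c2cc(Cl)ccc2O)c(Cl)c1`: 30200 nM
compound 2 `CCCCCCCCC(C)Nc1ccc(NC(=O)c2cc(Cl)ccc2O)c(Cl)c1`: 21900 nM
compound 3 `CC1(Nc2ccc(NC(=O)c3cc(Cl)ccc3O)c(Cl)c2)CCCC1`: 157000 nM

Compound 1 stands second highest of the three numbers; nearest is compound 2, a 1.4-fold lower number from compound 1 to compound 2 (0.14 log units; within the scatter), furthest compound 3, a 5.2-fold higher number from compound 1 to compound 3 (0.72 log units; beyond the scatter).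

Compound 4 `CN(C)c1ccc(CNc2ccc(NC(=O)c3cc(Cl)ccc3O)c(Cl)c2)cc1` differs from compound 1 as follows: 4-(dimethylamino)phenyl in place of methyl on a saturated chain carbon bound to a nitrogen on an aromatic ring.

For the measured compounds named here, two steps bear on it. The step from compound 1 to compound 2 changes the same saturated chain carbon bound to the nitrogen and stays within the scatter. The step from compound 1 to compound 3 changes the nitrogen substituent as a whole and gives a modest higher number. Hence for compound 4 a small step, if any, is expected in this assay, leaning to a higher number: a 1.2-fold higher number from compound 1 to compound 4 (0.08 log units; within the scatter). Compound 4 is expected to give 36000 nM, range 12000 nM to 110000 nM.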

Compound 4, half-maximal cytotoxic concentration: 24500 nM
Compound 4: middle estimate off by 1.5-fold (0.17 log units), on the high side, and the stated range covers the measured number.
By their numbers in this assay, from the lowest: compounds 2, 4 and 1 (each within the scatter of the next); then compound 3.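

In this assay, an aromatic ring carried on this saturated chain carbon bound to the nitrogen stays close to compound 1: 4-(dimethylamino)phenyl in place of methyl leaves the number within the scatter (a 1.2-fold lower number from compound 1 to compound 4 (0.09 log units; within the scatter)). Like the octyl step (a 1.4-fold lower number from compound 1 to compound 2 (0.14 log units; within the scatter)), this change produces no shift that can be read, so the 1-methylcyclopentyl of compound 3 remains the only change beyond the scatter (a 5.2-fold higher number from compound 1 to compound 3 (0.72 log units; beyond the scatter)). Nothing measured here accounts for this flat response.

Open, as far as these compounds go, is whether a plain phenyl without the dimethylamino group would stay as close to compound 1. Equally open, from the compounds shown here alone, is whether a carboxylic acid or a morpholine on that ring would do so.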